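A few compounds are considered here, and "the series" means these few. Any claim that something is new, unique, unknown or untested is made for them only; others in the source may bear on it.

Working notes on the series. Compound 1 `Cc1nn(C)c(Oc2ccc(Cl)cc2)c1/C=N\CCCCCOc1cc2oc(=O)cc(C)c2cc1Cl` and compound 2 `Cc1nn(C)c(Oc2ccc(F)cc2F)c1/C=N\CCCCCCOc1cc2oc(=O)cc(C)c2cc1Cl` share the same core and differ in the halogenated aryl group on the oxygen and in the length of the linking chain. In a functional assay on SMMC-7721 cells (Homo sapiens) for antiproliferative activity, read by MTT assay, with a stated time of 72 h (on this read-out higher numbers stand for weaker inhibition and lower numbers for stronger inhibition), compound 1 gives 17500 nM. Compound 2 returns only a limit of this assay, > 25000 nM, and no number stands for it. Compound 2 therefore sits at the limit of > 25000 nM in this assay, at which 1 of the 2 values shown sits. Compound 3 `Cc1nn(C)c(Oc2ccc(Br)cc2)c1/C=N\CCCCCCOc1cc2oc(=O)cc(C)c2cc1Cl` is not yet measured; it differs from compound 2 by 4-bromophenyl in place of 2,4-difluorophenyl on an oxygen on an aromatic ring. Among the measured compounds shown here, no measured pair here shows the effect of such a change. With compound 2 at a limit, the step from compound 2 to compound 3 is expected to be an at least 1.1-fold lower number from compound 2 to compound 3 (0.05 log units; that floor lies within the scatter), no more than the scatter in either direction. Compound 3 is expected to give about 22000 nM in this assay, within 8000 nM to 60000 nM, with a fair chance that only a limit is reported.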

Compound 3, half-maximal inhibitory concentration: 3090 nM
Compound 3: the middle estimate sits 7.1-fold (0.85 log units) above what was measured; measured number below the stated range.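

Among the compounds shown here, this is the first pair that differs in one place only: on an oxygen on an aromatic ring, 4-bromophenyl in place of 2,4-difluorophenyl gives, in this assay, an at least 8.0-fold lower number from compound 2 to compound 3 (0.90 log units; beyond the scatter). With the linking chain and the shared core unchanged, the read-out therefore responds to the aryl group at this position, by more than the scatter. The true size of the step stays unknown and only its floor can be read, because compound 2 stands at a limit: the limit of > 25000 nM in this assay, at which 1 of the 3 values shown sits.

The pair does not separate the entry of the bromine from the departure of the two fluorines, and an unsubstituted phenyl at this position would bear on that question. From the compounds shown here alone, the contribution of the linking chain also stays open, as compound 1 and compound 3 differ in two places, and a longer chain on the same core would bear on it.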